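Adding a methoxy to a weakly cytotoxic pair

A few compounds are considered here, and "the series" means these few. Any claim that something is new, unique, unknown or untested is made for them only; others in the source may bear on it.

Measured so far:
Compound 1 `COc1cccc(/C=C2\CCC/C(=C\c3cccc(Cl)c3)C2=O)c1OC` gives 21400 nM
Compound 2 `COc1cccc(/C=C2\CCC/C(=C\c3cccc(OC)c3OC)C2=O)c1` gives 16400 nM

In an ADME assay on NHDF cells (Homo sapiens) for cytotoxicity, read by MTT assay, with a stated time of 72 h (on this read-out higher numbers stand for weaker inhibition and lower numbers for stronger inhibition), compound 2 gives 16400 nM and stands within the scatter of compound 1, which gives 21400 nM on the same read-out. Compound 3 `COc1ccc(/C=C2\CCC/C(=C\c3cccc(OC)c3OC)C2=O)cc1OC` differs from compound 2 by one change, methoxy in place of hydrogen on an aromatic carbon. Going by the values given here, the only measured step that bears on it also brought in a methoxy, there in place of chloro (a 1.3-fold lower number from compound 1 to compound 2 (0.12 log units; within the scatter)). One small step is thin evidence, so no shift beyond the scatter is expected in this assay for this change. The expected step is small (a 1.0-fold lower number from compound 2 to compound 3 (0.01 log units; within the scatter)). Compound 3 is estimated at 16000 nM, with an expected range from 6500 nM to 40000 nM on repeated measurement.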

Compound 3, half-maximal inhibitory concentration: 14900 nM
Estimate against measurement, compound 3: 1.1-fold (0.03 log units) above; measured number inside the range.
By their numbers in this assay, from the lowest: compounds 3, 2 and 1 (each within the scatter of the next).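

Putting a methoxy in place of hydrogen, ortho to a methoxy group and para to a large group, gives a 1.1-fold lower number from compound 2 to compound 3 (0.04 log units; within the scatter) in this assay. Unlike the earlier step, which exchanged chloro for methoxy, this one adds a group at an unsubstituted aromatic carbon, and the number still does not shift beyond the scatter. Nothing available here explains the size of this step. From the compounds shown here alone, whether an amine or a carboxylic acid at this position would shift the number beyond the scatter remains open.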